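The source may report more compounds than this note shows. Statements on the series, on what has been measured and on what is new or still open speak of the compounds shown alone.

Within a functional assay on A549 cells (Homo sapiens) for cytotoxicity, read by MTT assay (on this read-out higher numbers stand for weaker inhibition and lower numbers for stronger inhibition), compound 3 `O=c1c(-c2nnc(COc3ccc4ccccc4c3)o2)cn(C2CC2)c2cc(N3CCNCC3)c(F)cc12` gives 16 ug/mL, the lowest of the three numbers recorded. Compound 2 `O=c1c(-c2nnc(COc3ccccc3)o2)cn(C2CC2)c2cc(N3CCNCC3)c(F)cc12` gives 48.6 ug/mL, and compound 1 `CCn1cc(-c2nnc(COc3ccc4ccccc4c3)o2)c(=O)c2cc(F)c(N3CCNCC3)cc21` gives 80.2 ug/mL. Both measured steps point to compound 3: a 5.0-fold lower number from compound 1 to compound 3 (0.70 log units; beyond the scatter), and a 3.0-fold lower number from compound 2 to compound 3 (0.48 log units; beyond the scatter).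

Compound 4 `O=c1c(-c2nnc(-c3ccccc3)o2)cn(C2CC2)c2cc(N3CCNCC3)c(F)cc12` differs from compound 3 by phenyl in place of ((naphthalen-2-yl)oxy)methyl on an aromatic carbon. Among the measured compounds shown here, only one measured step touches the same part of the molecule: the change from a phenyl to a naphthalen-2-yl on that oxygen, a 3.0-fold lower number from compound 2 to compound 3 (0.48 log units; beyond the scatter), where the larger ring system brought the lower number. For the measured compounds named here, compound 4 goes the other way and further, dropping the oxygen-bearing linker and the second ring together; no measured pair shows a directly attached aryl in this place. A higher number than compound 3 is therefore expected for compound 4, plausibly at least as large as the step back to compound 2, with the linker loss adding uncertainty. Compound 4 is estimated at 55 ug/mL, within 20 ug/mL to 150 ug/mL, an expected step of a 3.4-fold higher number from compound 3 to compound 4 (0.54 log units; beyond the scatter).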

Compound 4, half-maximal inhibitory concentration: 46 ug/mL
Compound 4: the middle estimate sits 1.2-fold (0.08 log units) above what was measured; the range from low to high includes it.
By their numbers in this assay, from the lowest: compound 3; then compounds 4, 2 and 1 (each within the scatter of the next).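

In this assay, phenyl in place of ((naphthalen-2-yl)oxy)methyl on this aromatic carbon gives a 2.9-fold higher number from compound 3 to compound 4 (0.46 log units; beyond the scatter) and shows that the lower number of compound 3 does not survive this exchange. Phenyl in place of phenoxymethyl gives a 1.1-fold lower number from compound 2 to compound 4 (0.02 log units; within the scatter) and so leaves compound 2 and compound 4 level, which means that among these groups only ((naphthalen-2-yl)oxy)methyl stands apart at this place. No measurement here offers an explanation for this pattern.

The compounds shown leave open how a group without an aromatic ring on this carbon, such as a short alkyl chain or an amine, would read. They also leave open whether naphthalen-2-yl attached directly to this carbon would match compound 3 or stay level with compound 4.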